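The compounds below may be only part of what the source reports. "The series", "measured", "known", "first", "only" and "open" are said of these compounds alone.

Compound 3 `CCc1nc2c(-c3ccc(Cl)cc3Cl)ccnc2n1C(CC)CC` gives the highest number of the three compounds measured in an assay for binding affinity to Corticotropin releasing factor receptor (Rattus norvegicus) (on this read-out lower numbers stand for stronger inhibition and higher numbers for weaker inhibition), at 1 nM. Compound 1 `CCc1nc2c(-c3ccc(Cl)cc3Cl)ccnc2n1[C@H](CC)C1CC1` gives 0.2 nM in this assay, and compound 2 `CCCC(C)n1c(CC)nc2c(-c3ccc(Cl)cc3Cl)ccnc21` gives 0.5 nM. The gap between compound 2 and compound 3 is a 2.0-fold higher number from compound 2 to compound 3 (0.30 log units; within the scatter), whereas the gap between compound 1 and compound 3 is a 5.0-fold higher number from compound 1 to compound 3 (0.70 log units; beyond the scatter), and between compound 1 and compound 2 it is a 2.5-fold higher number from compound 1 to compound 2 (0.40 log units; beyond the scatter).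

Compound 4 `CCc1nc2c(-c3ccc(Cl)cc3Cl)ccnc2n1C(CCOC)C1CC1` is not yet measured. Its change from compound 3 is 1-cyclopropyl-3-methoxypropyl in place of pentan-3-yl on an aromatic nitrogen. Going by the values given here, of the measured steps, the one from compound 1 to compound 3 bears most directly on it, since it swaps the same cyclopropyl-bearing group for pentan-3-yl, and it was a modest step in the direction of a higher number. Reversing that swap while also bringing in the methoxy-bearing chain is therefore expected to lower the number for compound 4, by a step of about a 3.3-fold lower number from compound 3 to compound 4 (0.52 log units; beyond the scatter); there is no measured step for the methoxy group itself. Compound 4 is thus estimated at 0.3 nM, with a range from 0.1 nM to 1.5 nM.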

Compound 4, inhibition constant: 1.5 nM
Beside the measured number, compound 4's estimate is 5.0-fold (0.70 log units) below it; measured number inside the range.
By their numbers in this assay, from the lowest: compound 1; then compounds 2, 3 and 4 (each within the scatter of the next, the first and the last beyond it).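

On the aromatic nitrogen, the 1-cyclopropyl-3-methoxypropyl group of compound 4 does not hold the level of the 1-cyclopropylpropyl group: this assay shows a 7.5-fold higher number from compound 1 to compound 4 (0.88 log units; beyond the scatter) for this change, and a 3.0-fold higher number from compound 2 to compound 4 (0.48 log units; beyond the scatter) against 1-methylbutyl. A cyclopropyl ring on this substituent is thus not enough on its own to give the low number of compound 1, since the swap for pentan-3-yl reads only as a 1.5-fold higher number from compound 3 to compound 4 (0.18 log units; within the scatter) and so separates neither group from the other. Nothing available accounts for this result.

The compounds shown do not separate the methoxy oxygen from the longer chain, and neither a plain butyl chain nor a hydroxyl or an amine at the chain end is among them. From the compounds shown here alone, compound 1 is drawn with a defined configuration at the branching carbon and compound 4 without one, so the share of that difference in the step also stays open.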